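This account rests on a few compounds, and the source may have more. Where it says the series, first, only, none or still open, it means among the compounds named here.

Measured compounds:
- compound 1 `CCCCNc1nc(N)nc(C)c1CCCN1CCCCCC1`: 178 nM
- compound 2 `C#Cc1c(C)nc(N)nc1NCCCC`: 4900 nM
- compound 3 `CCCCNc1nc(N)nc(C)c1CC`: 1660 nM

In an assay on HEK293 cells for agonist activity at Toll-like receptor 8 (Homo sapiens), read by spectrophotometry (on this read-out lower numbers stand for an effect already at smaller amounts and higher numbers for an effect only at larger amounts of compound), compound 3 gives the second highest of the three numbers. Among the compounds with values here, its nearest neighbour is compound 2, which differs from it only in ethynyl against ethyl and gives the higher number; the one measured step, a 3.0-fold lower number from compound 2 to compound 3 (0.47 log units; beyond the scatter), is modest but beyond the scatter. Compound 1 gives the lowest number of the three, well below compound 3.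

The next compound is compound 4 `CCCCNc1nc(N)nc(C)c1CCCN1CCCC1`. It keeps everything of compound 3 and differs in one place: (pyrrolidin-1-yl)methyl in place of hydrogen on a saturated chain carbon, two bonds along the chain from an aromatic carbon. Within the data shown here, no measured step tells exactly what this change does, because compound 1 differs from compound 3 in more than the one place. Still, compound 1 carries a chain ending in a saturated nitrogen ring on the same position and gives 178 nM, far lower than compound 3, so a sizeable drop in the number is expected in this assay. A step of a 5.9-fold lower number from compound 3 to compound 4 (0.77 log units; beyond the scatter) is therefore expected, landing compound 4 near compound 1 but with wide uncertainty, since the ring size differs. For compound 4 the estimate is 280 nM, with a range from 80 nM to 900 nM.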

Compound 4, half-maximal effective concentration: 110 nM
Compound 4: middle estimate off by 2.5-fold (0.41 log units), on the high side; measured number inside the range.
By their numbers in this assay, from the lowest: compounds 4 and 1 (each within the scatter of the next); then compound 3; then compound 2.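

In this assay, within the data shown here, placing (pyrrolidin-1-yl)methyl on a saturated chain carbon, two bonds along the chain from an aromatic carbon, gives a 15-fold lower number from compound 3 to compound 4 (1.18 log units; beyond the scatter), which is the first single-place measure of what this group does at this position, and the effect is large. Exchanging the ring at the end of the chain has far less effect: the change to pyrrolidin-1-yl from azepan-1-yl gives a 1.6-fold lower number from compound 1 to compound 4 (0.21 log units; within the scatter), so these two rings cannot be told apart in this assay even though one is five-membered and the other is larger. At this position, then, the large step comes with adding the group to the short chain of compound 3, while the choice between these two saturated nitrogen rings makes no measurable difference. No measurement at hand gives a reason for the large step.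

Still open, going by these compounds, is whether the ring nitrogen matters at all, which a cyclopentyl group with no nitrogen or an open-chain dimethylamino group at the same chain end could show. Also open, on these data alone, are the effects of a longer chain between the aromatic carbon and the ring, and of other rings such as morpholine.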